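Pyridin-2-yl in place of 4-methoxyphenyl: expected cytotoxicity

A few compounds are considered here, and "the series" means these few. Any claim that something is new, unique, unknown or untested is made for them only; others in the source may bear on it.

Measured in a functional assay on HeLa cells (Homo sapiens) for cytotoxicity, read by MTT assay, with a stated time of 24 h; on this read-out higher numbers stand for weaker inhibition and lower numbers for stronger inhibition:
compound 1 `COc1cccc(/C=C2\SC(=O)N(Cc3ccc(C(=O)O)cc3)C2=O)c1` gives 48000 nM
compound 2 `COc1ccc(/C=C2\SC(=O)N(Cc3ccc(C(=O)O)cc3)C2=O)cc1` gives 40000 nM
compound 3 `COc1cc(/C=C2\SC(=O)N(Cc3ccc(C(=O)O)cc3)C2=O)cc(OC)c1OC` gives 30000 nM

Compound 2 holds the second highest of the three numbers; its gaps to compound 1 and to compound 3 both lie within the scatter, so the three compounds are not separable on this assay. Compound 4 `O=C(O)c1ccc(CN2C(=O)S/C(=C\c3ccccn3)C2=O)cc1` differs from compound 2 by pyridin-2-yl in place of 4-methoxyphenyl on a double-bonded chain carbon bound to a double-bonded ring carbon. Among the compounds with values here, the only measured step at this position, a 1.2-fold lower number from compound 1 to compound 2 (0.08 log units; within the scatter), concerns a move of the methoxy group and stays within the scatter; no measured step exchanges the aryl ring for a heteroaryl ring, so it carries little weight here. The expectation for compound 4 is therefore a step of no change at the digits printed from compound 2 to compound 4 (within the scatter), that is none beyond the scatter. Compound 4 is estimated at 40000 nM, with a range from 15000 nM to 100000 nM.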

Compound 4, half-maximal inhibitory concentration: 62000 nM
Compound 4: middle estimate off by 1.6-fold (0.19 log units), on the low side; the range from low to high includes it.
By their numbers in this assay, from the lowest: compounds 3, 2, 1 and 4 (each within the scatter of the next, the first and the last beyond it).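

Pyridin-2-yl on a double-bonded chain carbon bound to a double-bonded ring carbon gives a 1.6-fold higher number from compound 2 to compound 4 (0.19 log units; within the scatter) and a 1.3-fold higher number from compound 1 to compound 4 (0.11 log units; within the scatter), so both steps stay within the scatter. The position therefore shows no separable change with a ring exchange, not only with a move of the methoxy group. No evidence on the origin of these numbers is available.

Still open, on these data alone, is whether an amine or a carboxylic acid on this ring, or a saturated cyclohexyl ring in its place, would move the number beyond the scatter. Pyridin-3-yl and pyridin-4-yl also remain open.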